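A few compounds are considered here, and "the series" means these few. Any claim that something is new, unique, unknown or untested is made for them only; others in the source may bear on it.

Measured so far in a functional assay on MCF7 cells (Homo sapiens) for antiproliferative activity, read by MTT assay, with a stated time of 24 h; a lower number here means a stronger inhibitor, a higher number a weaker inhibitor:
- compound 1 `Cc1ccc(-c2nn(-c3ccccc3)cc2-c2nc3ccccc3n2S(=O)(=O)c2ccccc2)cc1` gives 830 nM
- compound 2 `Cc1ccc(-c2nn(-c3ccccc3)cc2-c2nc3ccccc3n2S(=O)(=O)c2ccc(C(F)(F)F)cc2)cc1` gives 2340 nM
- compound 3 `O=S(=O)(c1ccccc1)n1c(-c2cn(-c3ccccc3)nc2-c2ccc(F)cc2)nc2ccccc21` gives 690 nM

Compound 3 at 690 nM sits level with compound 1 within the scatter (a 1.2-fold lower number from compound 1 to compound 3 (0.08 log units; within the scatter)), and its number is clearly smaller than that of compound 2 at 2340 nM on these values.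

Compound 4 `COc1ccc(S(=O)(=O)n2c(-c3cn(-c4ccccc4)nc3-c3ccc(F)cc3)nc3ccccc32)cc1` is compound 3 with methoxy in place of hydrogen on an aromatic carbon, para to a large group, so phenylsulfonyl becomes (4-methoxyphenyl)sulfonyl (methoxy in place of hydrogen on an aromatic carbon).

Going by the values given here, no methoxy compound has been measured yet. The nearest guide is trifluoromethyl in place of hydrogen on that same phenylsulfonyl, which gave a modest rise (a 2.8-fold higher number from compound 1 to compound 2 (0.45 log units; beyond the scatter)). That is a different group in a different parent compound, so it hints at direction more than size. The fluoro in place of methyl step concerns another group and says little here.

Among the compounds with values here, with compound 2 at 2340 nM as the only guide, a small rise in this assay is expected for compound 4, possibly none beyond the scatter. The estimated step is a 1.4-fold higher number from compound 3 to compound 4 (0.14 log units; within the scatter) for now. The expected value for compound 4 is 950 nM (estimated range 350 nM to 2400 nM).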

Compound 4, half-maximal inhibitory concentration: 530 nM
Beside the measured number, compound 4's estimate is 1.8-fold (0.25 log units) above it; the measured number falls inside the stated range.
By their numbers in this assay, from the lowest: compounds 4, 3 and 1 (each within the scatter of the next); then compound 2.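

In this assay, methoxy in place of hydrogen on the phenylsulfonyl ring, para to a large group, gives a step within the scatter (a 1.3-fold lower number from compound 3 to compound 4 (0.11 log units; within the scatter)), so compound 3 and compound 4 stand level. This position can therefore carry a group larger than hydrogen with no measurable loss, which the earlier trifluoromethyl step (a 2.8-fold higher number from compound 1 to compound 2 (0.45 log units; beyond the scatter)) did not suggest, although that step was made in a different parent and the two steps cannot be matched exactly. Nothing available here explains why the two groups gave different results.

Going by these compounds, whether an amine or a carboxylic acid on this same aromatic carbon would also leave the number unmoved remains open. It is also unknown whether methoxy would give the same result in compound 1, or whether a longer chain in place of methoxy would be accepted.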